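From Fluoro to Bromo: An Expectation for Compound 4

A few compounds are considered here, and "the series" means these few. Any claim that something is new, unique, unknown or untested is made for them only; others in the source may bear on it.

Three compounds have been measured in a functional assay on MDA-MB-231 cells (Homo sapiens), read by fluorescence and BrdU incorporation, with a stated time of 48 h, tested at 25 uM; on this read-out higher numbers stand for a weaker effect at the one concentration tested and lower numbers for a stronger effect:
compound 1 `COc1cc(OC)c(C(=O)/C=C/c2ccccc2)c(OC)c1` gives 23%;
compound 2 `COc1cc(OC)c(C(=O)/C=C/c2ccc(Cl)cc2)c(OC)c1` gives 2.1%;
compound 3 `COc1cc(OC)c(C(=O)/C=C/c2ccc(F)cc2)c(OC)c1` gives 10%.

Among these three numbers compound 3 stands second highest in this assay: its nearest neighbour is compound 2, a gap within the scatter, and its furthest is compound 1, a gap beyond the scatter.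

Compound 4 `COc1cc(OC)c(C(=O)/C=C/c2ccc(Br)cc2)c(OC)c1` has not yet been measured. It differs from compound 3 in one place: bromo in place of fluoro on an aromatic carbon.

Among the measured compounds shown here, the only measured swap of one halogen for another is a number 7.9 percentage points higher from compound 2 to compound 3 (within the scatter), which lies within the scatter. For the measured compounds named here, the steps that bear on placing a halogen at this carbon are a number 20.9 percentage points lower from compound 1 to compound 2 (beyond the scatter) and a number 13 percentage points lower from compound 1 to compound 3 (beyond the scatter), both beyond the scatter and both downward, so a halogen here goes with a stronger effect than hydrogen, while chloro and fluoro cannot be told apart. Bromo is therefore expected to sit in the same region, and the step of a number 5 percentage points lower from compound 3 to compound 4 (within the scatter) is expected to be small and within the scatter. Compound 4 is estimated at 5%, with a range from 0% to 15%.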

Compound 4, a percentage reported as activity, at one concentration (the size of the read-out at that concentration, not a potency): 44%
Estimate against measurement, compound 4: 39 percentage points below, outside the stated range (above it).
By their numbers in this assay, from the lowest: compounds 2 and 3 (each within the scatter of the next); then compound 1; then compound 4.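

In this assay the three halogens at this aromatic carbon, para to a large group, do not form one class: bromo in place of fluoro gives a number 34 percentage points higher from compound 3 to compound 4 (beyond the scatter), and bromo in place of chloro gives a number 41.9 percentage points higher from compound 2 to compound 4 (beyond the scatter), so the identity of the halogen matters in a way the chloro and fluoro pair did not reveal. Bromo also reverses the direction seen for the other two halogens when they replace hydrogen, giving a number 21 percentage points higher from compound 1 to compound 4 (beyond the scatter), so a halogen at this carbon does not in itself go with a stronger effect. Nothing available here accounts for this break at bromo.

From the compounds shown here alone, it remains open how an iodo, methoxy or amino group at this carbon would read. The compounds shown also leave open whether the break at bromo would persist on a core carrying other groups.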